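The source may hold more compounds than are shown below. What is called first, only, known or untested is meant among the compounds shown, and "the series" means these compounds.

Measured so far in a functional assay on MCF7 cells (Homo sapiens) for inhibition, read by sulforhodamine B assay; on this read-out lower numbers stand for stronger inhibition and higher numbers for weaker inhibition:
- compound 1 `O=C1C(Nc2ccccc2)=CC(=O)c2c1nc1n2[C@H]2OC[C@@H](O)[C@H]2OC1`: > 4000 nM (a limit, not a number)
- compound 2 `CCOc1ccc(NC2=CC(=O)c3c(nc4n3[C@H]3OC[C@@H](O)[C@H]3OC4)C2=O)cc1`: > 4000 nM (a limit, not a number)
- compound 3 `O=C1C(Nc2cccc(Cl)c2)=CC(=O)c2c1nc1n2[C@H]2OC[C@@H](O)[C@H]2OC1`: 2970 nM

Going by the values given here, compound 3 holds the only true number of the three, 2970 nM. Compound 1 and compound 2 stay at the limit of > 4000 nM in this assay, at which 2 of the 3 values shown sit.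

Next in the series is compound 4 `O=C1C(Nc2cccc(F)c2)=CC(=O)c2c1nc1n2[C@H]2OC[C@@H](O)[C@H]2OC1`, which differs from compound 3 by fluoro in place of chloro on an aromatic carbon, meta to a large group.

Among the compounds with values here, two measured steps bear on this change, and neither gives more than a floor. The closest is an at least 1.3-fold lower number from compound 1 to compound 3 (0.12 log units; that floor lies within the scatter), where the same aromatic carbon carries chloro in place of hydrogen. The other is an at least 1.3-fold lower number from compound 2 to compound 3 (0.12 log units; that floor lies within the scatter), which swaps the whole aryl group on the amine nitrogen. The step that the two limits leave unreadable from compound 1 to compound 2 adds nothing to the size. With so little resolved in this assay, no step beyond the scatter can be justified, and any drift is expected toward a higher number, back toward compound 1.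

The expected change is a 1.2-fold higher number from compound 3 to compound 4 (0.08 log units; within the scatter), which stays small. For compound 4 the estimated value is 3600 nM, with an expected range of 1800 nM to 7000 nM.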

Compound 4, half-maximal inhibitory concentration: > 4000 nM
Compound 4: a limit, no number (the forecaster's own chance of this, stated with the estimate: 45%); at least 1.1-fold (0.04 log units) between middle value and limit.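

In this assay, fluoro in place of chloro on the aromatic carbon meta to a large group gives an at least 1.3-fold higher number from compound 3 to compound 4 (0.12 log units; that floor lies within the scatter), so this one-atom exchange has only a floor and no measured size. Compound 3 remains the only compound in the set with a true number, while compound 1, compound 2 and compound 4 all share one ceiling: the limit of > 4000 nM in this assay, at which 3 of the 4 values shown sit.

The steps linking compound 4 to compound 1 and compound 2 cannot be read, as both ends of each are limits, so fluoro cannot be ordered against hydrogen or against the 4-ethoxyphenyl group.

Compound 3 gives 2970 nM. From the compounds shown here alone, whether chloro on this carbon marks a real gain remains open, as every step to compound 3 is a floor within the scatter. Bromo or trifluoromethyl on the same aromatic carbon would show whether a true number is confined to chloro, and a carboxylic acid or an amine there would test the same position with a very different group.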